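Bromo for chloro on the pendant ring, now at a second place

The compounds below may be only part of what the source reports. "The series", "measured", "known", "first", "only" and "open" are said of these compounds alone.

Measured so far in a functional assay on CCRF-CEM cells (Homo sapiens) for inhibition; a higher number here means a weaker inhibitor, a lower number a stronger inhibitor:
Compound 1 `O=C1/C(=C/c2cccc(Cl)c2)CCCc2ccccc21`: 9440 nM
Compound 2 `O=C1/C(=C/c2ccc(Cl)cc2)CCCc2ccccc21`: 15100 nM
Compound 3 `O=C1/C(=C/c2cccc(Br)c2)CCCc2ccccc21`: 8900 nM

These three numbers lie within the usual scatter of one another, so nothing about their order can be read from them. Compound 1 and compound 2 have the same atoms joined differently; the difference between the two cores is not broken down here. Compound 3 differs from compound 1 by one change, (bromo in place of chloro on an aromatic carbon), and that change gave a 1.1-fold lower number from compound 1 to compound 3 (0.03 log units; within the scatter).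

The unmeasured compound 4 `O=C1/C(=C/c2ccc(Br)cc2)CCCc2ccccc21` differs from compound 2 by bromo in place of chloro on an aromatic carbon. This is the same kind of change as from compound 1 to compound 3, but not the same: there the place was meta to a large group, here it is para to a large group. Since the measured step was within the scatter, the expected step is also small, a 1.1-fold lower number from compound 2 to compound 4 (0.03 log units; within the scatter), resting on compound 1 at 9440 nM going to compound 3 at 8900 nM. Compound 4 is therefore estimated at 14000 nM, between 7000 nM and 28000 nM.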

Compound 4, half-maximal inhibitory concentration: 17100 nM
Estimate against measurement, compound 4: 1.2-fold (0.09 log units) below; measured number inside the range.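

In this assay, bromo in place of chloro on an aromatic carbon, para to a large group, gave a 1.1-fold higher number from compound 2 to compound 4 (0.05 log units; within the scatter). Set beside the earlier step, this one tells the same story, with neither step separating the two halogens: the same change on two cores in this assay, a 1.1-fold lower number (0.03 log units; within the scatter) from compound 1 to compound 3 and a 1.1-fold higher number (0.05 log units; within the scatter) from compound 2 to compound 4, 1.2-fold (0.08 log units) apart, within the scatter of two such steps So across these two pairs the swap carries over from one core to the other as a change too small to read, but this shows only that it did nothing measurable in either place, which is weak proof that a change of real size would carry over in the same way, and it says nothing about any other core.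

The compounds shown carry only chloro and bromo on the pendant ring, so it stays open whether a fluoro, a methoxy or a carboxylic acid in these places would give a step beyond the scatter. Also open, from the compounds shown here alone, is whether an amine elsewhere on the shared core would do so.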